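Halogen exchange at the aromatic carbon: bromo, chloro, fluoro

The source may report more compounds than this note shows. Statements on the series, on what has been measured and on what is new or still open speak of the compounds shown alone.

Among the compounds with values here, compound 2 `COC(=O)[C@@]1(C)CC[C@@H]2C3=C1CC[C@@H](C)[C@]3(C)C[C@@H]1c3cc(Cl)ccc3N[C@H]21` gives 38000 nM in a functional assay on SW1573 cells (Homo sapiens) for inhibition, read by sulforhodamine B assay, with a stated time of 48 h; a higher number here means a weaker inhibitor of growth, a lower number a stronger inhibitor of growth; this is the lowest of the two numbers so far, but compound 1 `COC(=O)[C@@]1(C)CC[C@@H]2C3=C1CC[C@@H](C)[C@]3(C)C[C@@H]1c3cc(Br)ccc3N[C@H]21` gives 45000 nM, and the step of a 1.2-fold lower number from compound 1 to compound 2 (0.07 log units; within the scatter) lies within the scatter, so no order between the two is claimed. Compound 3 `COC(=O)[C@@]1(C)CC[C@@H]2C3=C1CC[C@@H](C)[C@]3(C)C[C@@H]1c3cc(F)ccc3N[C@H]21` continues the same exchange: fluoro in place of chloro on an aromatic carbon. Within the data shown here, the only measured step that bears on this change is the earlier halogen swap a 1.2-fold lower number from compound 1 to compound 2 (0.07 log units; within the scatter), which stayed within the scatter. A second exchange of the same kind is therefore expected to move this assay little, with no direction that would reach beyond the scatter. For compound 3 the estimate in this assay is 42000 nM, with a range from 20000 nM to 90000 nM. The expected step is a 1.1-fold higher number from compound 2 to compound 3 (0.04 log units; within the scatter).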

Compound 3, concentration for 50% growth inhibition: 27000 nM
For compound 3 the middle estimate is 1.6-fold (0.19 log units) above the measured one; low and high end bracket the measured number.
By their numbers in this assay, from the lowest: compounds 3, 2 and 1 (each within the scatter of the next).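

With fluoro in place, this aromatic carbon has now carried three halogens in this assay, and the new steps are a 1.4-fold lower number from compound 2 to compound 3 (0.15 log units; within the scatter) and a 1.7-fold lower number from compound 1 to compound 3 (0.22 log units; within the scatter). Even the exchange of bromo for fluoro, which spans the whole halogen set shown, stays within the scatter, so this assay does not separate the three compounds, and the earlier single swap of bromo for chloro now extends to all three halogens shown. No supporting data are available to account for the values of these three compounds.

Still open, on these data alone, is whether a group other than a halogen on this aromatic carbon, such as an amine, a methoxy group or a carboxylic acid, would give a step beyond the scatter in this assay. The compounds shown also leave open whether leaving this carbon with only hydrogen would differ from the halogens.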